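Rearranging one side chain: from compound 2 to compound 4

The compounds below may be only part of what the source reports. "The series", "measured", "known", "first", "only" and "open" are said of these compounds alone.

Compound 1 `O=C(Nc1ccc(C(=O)N2CCCN(CCN3CCCC3)c3sccc32)cc1)c1ccccc1-c1ccccc1`: > 0.3 mg/kg (a limit, not a number)
Compound 2 `CN1CCN(C(=O)CCCOc2cc(C(=O)N3CCCCc4sccc43)ccc2NC(=O)c2ccccc2-c2ccccc2)CC1`: 0.03 mg/kg
Compound 3 `COc1cc(C(=O)N2CCCC(N(C)C)c3sccc32)ccc1NC(=O)c1ccccc1-c1ccccc1`: > 0.3 mg/kg (a limit, not a number)

Going by the values given here, in a functional assay on the whole organism for antagonist activity, with Rattus norvegicus as the target (a lower number here means that less compound is needed, a higher number that more compound is needed for the effect), compound 2 gives 0.03 mg/kg, the only true number among the three measured compounds. Compound 1 is reported as > 0.3 mg/kg, which is a limit. Compound 3 is reported as > 0.3 mg/kg, also a limit. The picture so far is the limit of > 0.3 mg/kg in this assay, at which 2 of the 3 values shown sit.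

Compound 4 `CN(C)C1CCN(C(=O)COc2cc(C(=O)N3CCCCc4sccc43)ccc2NC(=O)c2ccccc2-c2ccccc2)CC1` is built from the same atoms as compound 2, joined differently: (4-(dimethylamino)piperidin-1-yl)carbonyl in place of 2-((4-methylpiperazin-1-yl)carbonyl)ethyl on a saturated chain carbon bound to an oxygen on an aromatic ring. A (4-(dimethylamino)piperidin-1-yl)carbonyl group takes the place of 2-((4-methylpiperazin-1-yl)carbonyl)ethyl, and the counts of hydrogen-bond donors and acceptors stay the same.

Among the compounds with values here, no measured pair shows what such a change does, so compound 2 at 0.03 mg/kg is the only anchor. In this assay no change beyond the usual scatter is expected, and the estimated step is a 1.3-fold higher number from compound 2 to compound 4 (0.12 log units; within the scatter). For compound 4 the expected value is 0.04 mg/kg, with an estimated range from 0.012 mg/kg to 0.15 mg/kg.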

Compound 4, dose for 50% inhibition: 0.02 mg/kg
The estimate for compound 4 lay 2.0-fold (0.30 log units) above the measured number; the measured number falls inside the stated range.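

Going by these compounds alone, this is the first pair in the set that differs in only one place, so it gives the first direct look at this side chain. In this assay, the two arrangements cannot be told apart: the step is a 1.5-fold lower number from compound 2 to compound 4 (0.18 log units; within the scatter). The same atoms can therefore be rearranged at this position, from 3-((4-methylpiperazin-1-yl)carbonyl)propyl to ((4-(dimethylamino)piperidin-1-yl)carbonyl)methyl, and the whole-animal result holds, although nothing measured here bears on why the two read alike.

Both side chains end in a ring-containing amide with two nitrogens, so this pair cannot say whether that feature matters. From the compounds shown here alone, it remains open how a chain ending in a carboxylic acid, or one carrying a morpholine in place of these rings, would behave at this position.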